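The compounds below may be only part of what the source reports. "The series", "measured", "known", "first", "only" and "open" are said of these compounds alone.

Measured so far in an assay for binding affinity to metabotropic glutamate receptor 5 (Rattus norvegicus); on this read-out lower numbers stand for stronger inhibition and higher numbers for weaker inhibition:
- compound 1 `N#Cc1ccccc1-c1cc(F)cc(-n2nnc(-c3ccccn3)n2)c1` — 4 nM
- compound 2 `Nc1ccccc1-c1cc(F)cc(-n2nnc(-c3ccccn3)n2)c1` — 7 nM
- compound 3 `Cc1ccc(-c2cc(F)cc(-n3nnc(-c4ccccn4)n3)c2)cn1` — 36 nM

Compound 3 holds the highest number of the three: a 5.1-fold higher number from compound 2 to compound 3 (0.71 log units; beyond the scatter) and a 9.0-fold higher number from compound 1 to compound 3 (0.95 log units; beyond the scatter), both beyond the scatter. Compound 4 `Nc1ccncc1-c1cc(F)cc(-n2nnc(-c3ccccn3)n2)c1` differs from compound 3 by 4-aminopyridin-3-yl in place of 6-methylpyridin-3-yl on an aromatic carbon. Going by the values given here, two measured steps bear on it. First, a 1.8-fold higher number from compound 1 to compound 2 (0.24 log units; within the scatter), so the amino group as such costs nothing. Second, a 5.1-fold higher number from compound 2 to compound 3 (0.71 log units; beyond the scatter), which compound 4 partly reverses: it keeps the ring nitrogen of compound 3 but carries the amino group of compound 2. A modest step down is therefore expected, a 3.0-fold lower number from compound 3 to compound 4 (0.48 log units; beyond the scatter). Compound 4 is estimated at 12 nM in this assay, expected range 4 nM to 40 nM.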

Compound 4, inhibition constant: 20 nM
Compound 4: the middle estimate sits 1.7-fold (0.22 log units) below what was measured; the range from low to high includes it.
By their numbers in this assay, from the lowest: compounds 1 and 2 (each within the scatter of the next); then compounds 4 and 3 (each within the scatter of the next).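

In this assay 4-aminopyridin-3-yl in place of 6-methylpyridin-3-yl gives a 1.8-fold lower number from compound 3 to compound 4 (0.26 log units; within the scatter) and so does not separate these two pyridine groups at this position. An amino group on the pyridine ring does not match 2-aminophenyl, as a 2.9-fold higher number from compound 2 to compound 4 (0.46 log units; beyond the scatter) shows, and the gap to 2-cyanophenyl is wider still, with a 5.0-fold higher number from compound 1 to compound 4 (0.70 log units; beyond the scatter) on the same aromatic carbon. No supporting data on hand account for these steps.

Still open, as far as these compounds go, is whether moving the amino group around the pyridine ring changes the gap to 2-aminophenyl. Also open, from the compounds shown here alone, is how a 2-methoxyphenyl group would read at this carbon.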